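The source may hold more compounds than are shown below. What is called first, only, known or untested is meant among the compounds shown, and "the series" means these compounds.

Measured so far in a functional assay on A549 cells (Homo sapiens) for inhibition, read by MTT assay and WST assay, with a stated time of 72 h, tested at 10 uM; on this read-out lower numbers stand for less inhibition of growth and higher numbers for more inhibition of growth at the one concentration tested:
compound 1 `O=C(Nc1ccc(Cl)cc1)Nc1ccc(Oc2ccc(-c3nccs3)cc2)cc1` gives 17.7%;
compound 2 `O=C(Nc1ccc(Oc2ccc(-c3nccs3)cc2)cc1)Nc1cccc(C(F)(F)F)c1` gives 71.5%;
compound 3 `Cc1ccc(NC(=O)Nc2ccc(Oc3ccc(-c4nccs4)cc3)cc2)cc1` gives 15.6%.

Compound 3 sits at the low end of these three numbers together with compound 1; the two are within the scatter of each other (a number 2.1 percentage points lower from compound 1 to compound 3 (within the scatter)), so no order between them can be claimed. Compound 2 stands far above both, as the step of a number 55.9 percentage points lower from compound 2 to compound 3 (beyond the scatter) shows.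

Compound 4 `O=C(Nc1ccc(Oc2ccc(-c3nccs3)cc2)cc1)Nc1cc(Br)cc(C(F)(F)F)c1` differs from compound 3 in one place: 3-bromo-5-(trifluoromethyl)phenyl in place of 4-methylphenyl on an amide-type nitrogen. The group that enters carries a trifluoromethyl on the phenyl, as does the group in compound 2, and it adds a bromine besides. Among the compounds with values here, two measured steps bear on this change. Going from compound 2 to compound 3 removes the trifluoromethyl-bearing phenyl and the number falls sharply (a number 55.9 percentage points lower from compound 2 to compound 3 (beyond the scatter)); going from compound 1 to compound 2 introduces it and the number rises sharply (a number 53.8 percentage points higher from compound 1 to compound 2 (beyond the scatter)). Within the data shown here, the bromine has no counterpart among the measured compounds, so its effect is unknown. A large upward step in this assay is therefore expected for compound 4, in the direction seen from compound 1 to compound 2. Compound 4 is estimated to give about 65%, in a range from 40% to 85%. The expected step is a number 49.4 percentage points higher from compound 3 to compound 4 (beyond the scatter).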

Compound 4, percent growth inhibition at one concentration: 81.7%
Compound 4: middle estimate off by 16.7 percentage points, on the low side, within the range that was stated.
By their numbers in this assay, from the lowest: compounds 3 and 1 (each within the scatter of the next); then compound 2; then compound 4.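

In this assay, the 3-bromo-5-(trifluoromethyl)phenyl group on the amide-type nitrogen places compound 4 far above the two compounds at the low end, with a number 66.1 percentage points higher from compound 3 to compound 4 (beyond the scatter) and a number 64 percentage points higher from compound 1 to compound 4 (beyond the scatter) as the large steps. Within the data shown here, the new information concerns the bromine, which had no measured counterpart earlier: bromo in place of hydrogen on an aromatic carbon gives a number 10.2 percentage points higher from compound 2 to compound 4 (beyond the scatter) and is a modest rise beyond the scatter, so this phenyl keeps its high reading with the added bromine and gains a little more. Nothing in the available data explains why either change acts as it does.

Going by these compounds, compound 2 and compound 4 both carry the trifluoromethyl group, so it stays open whether bromine would raise the number on a phenyl without that group, and whether trifluoromethyl itself accounts for the large rise. The compounds shown also leave open how this position would respond to a nitrile or a dimethylamino group in place of the bromine, or to a carboxylic acid on the phenyl.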